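The source may hold more compounds than are shown below. What is called first, only, known or untested is meant among the compounds shown, and "the series" means these compounds.

Compound 1 `COc1ccc(-c2cnc(NC(=O)c3cccnc3)n2C)cc1` was tested in a toxicity assay on THP-1 cells (Homo sapiens) for inhibition; on this read-out higher numbers stand for lower toxicity in this test and lower numbers for higher toxicity in this test. In this assay compound 1 reaches only the upper limit of the test, > 100000 nM, and no number below it. Compound 2 `COc1ccc(-c2ccc(NC(=O)c3ccc(F)cc3)nc2)cc1` shows the same picture, its value in this assay being the limit > 100000 nM rather than a number. Both measured values therefore sit at the limit of > 100000 nM in this assay, at which 2 of the 2 values shown sit. Compound 3 `COc1ccc(-c2cnc(NC(=O)c3ccc(Cl)cc3)n2C)cc1` differs from compound 1 by 4-chlorophenyl in place of pyridin-3-yl on a carbonyl carbon. With both known values at the limit, the step of a number no higher from compound 1 to compound 3 (the limit leaves the size open) is expected to stay within the scatter, and compound 3 is estimated at 100000 nM, between 40000 nM and 250000 nM.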

Compound 3, half-maximal cytotoxic concentration: > 100000 nM
Compound 3: only a limit was reported (the forecaster's own chance of this, stated with the estimate: 70%); the middle value sits exactly at the limit.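

Compound 1 and compound 3 both stop at a limit rather than a number, so no step between them can be read in this assay: the limit of > 100000 nM in this assay, at which 3 of the 3 values shown sit.

The compounds shown leave open whether 4-chlorophenyl in place of pyridin-3-yl changes the read-out at all.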